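Extending the Ester Chain Further in a Quinazoline Series

The compounds below may be only part of what the source reports. "The series", "measured", "known", "first", "only" and "open" are said of these compounds alone.

Of the compounds shown here, three of a shared core have been measured in a functional assay on A549 cells (Homo sapiens) for cytotoxicity, read by MTT assay, with a stated time of 24 h, tested at 60 uM; on this read-out higher numbers stand for a weaker effect at the one concentration tested and lower numbers for a stronger effect. Compound 1 `CCCCCCOC(=O)CCC(=O)N1CCN(CCCOc2cc3c(Nc4ccc(F)c(Cl)c4)ncnc3cc2OC)CC1` gives 63.6%. Compound 2 `CCCCCCCOC(=O)CCC(=O)N1CCN(CCCOc2cc3c(Nc4ccc(F)c(Cl)c4)ncnc3cc2OC)CC1` gives 35.7%. Compound 3 `CCCCCCCCCCCCOC(=O)CCC(=O)N1CCN(CCCOc2cc3c(Nc4ccc(F)c(Cl)c4)ncnc3cc2OC)CC1` gives 2%, the lowest of the three numbers; its nearest neighbour is compound 2, and compound 1 stands furthest from it. The three measured steps all run the same way: a number 27.9 percentage points lower from compound 1 to compound 2 (beyond the scatter), a number 61.6 percentage points lower from compound 1 to compound 3 (beyond the scatter) and a number 33.7 percentage points lower from compound 2 to compound 3 (beyond the scatter), each a lengthening of the chain on the ester side and each a fall in the read-out beyond the scatter.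

Compound 4 `CCCCCCCCCCCCCCCCCCOC(=O)CCC(=O)N1CCN(CCCOc2cc3c(Nc4ccc(F)c(Cl)c4)ncnc3cc2OC)CC1` is the next member of this line, not yet measured in this assay. It differs from compound 3 by hexyl in place of hydrogen on a saturated chain carbon, ten or more bonds along the chain from an oxygen next to a carbonyl group. The two steps that bear on it most directly are the ones that also add chain length at this end, from compound 1 to compound 3 and from compound 2 to compound 3, both large. Compound 3, however, already stands close to the bottom of the scale, so little room remains for a further drop, and any step is expected to stay within the scatter: a number 1 percentage points higher from compound 3 to compound 4 (within the scatter). Compound 4 is therefore estimated at 3%, in the range 0% to 14%.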

Compound 4, a percentage reported as activity, at one concentration (the size of the read-out at that concentration, not a potency): 87.2%
Estimate against measurement, compound 4: 84.2 percentage points below; measured number above the stated range.
By their numbers in this assay, from the lowest: compound 3; then compound 2; then compound 1; then compound 4.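

In this assay the added hexyl reverses the direction of the series (a number 85.2 percentage points higher from compound 3 to compound 4 (beyond the scatter)), so the fall running through compound 1, compound 2 and compound 3 does not carry on to compound 4. The reversal also overshoots the starting point of the series (a number 23.6 percentage points higher from compound 1 to compound 4 (beyond the scatter)) and clears the intermediate member by a wide margin (a number 51.5 percentage points higher from compound 2 to compound 4 (beyond the scatter)), which leaves compound 4 with the weakest effect of the four and shows that lengthening the chain at this position has no single direction of effect, with compound 4 going against the earlier fall. Nothing available on these compounds accounts for this turn.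

Among the compounds shown here, whether the read-out turns sharply or gradually stays open, since a propyl in place of the hexyl, or a nonyl-length extension placed differently, would fall within the stretch that only this one step spans. On these data alone, it is equally open whether a branched chain, or an amine or a carboxylic acid at the end of the chain, would keep the strong effect of compound 3 or lose it as compound 4 does.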